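Ether variation in the shared core: benzyloxy in place of trifluoroethoxy

The source may report more compounds than this note shows. Statements on the series, on what has been measured and on what is new or still open speak of the compounds shown alone.

Compound 1 `Nc1nc(OCC(F)(F)F)c2ncn(/C=C3/CC3(CO)CO)c2n1` shows no cytotoxicity up to the limit of an ADME assay on MOLT-3 cells (Homo sapiens) for cytotoxicity, with a stated time of 7 days; a lower number here means that less compound is tolerated, a higher number that more compound is tolerated: compound 1 gives > 20000 nM, which is a limit of the assay and not a number. Among the compounds with values here, its one measured neighbour, compound 2 `COCCOc1nc(N)nc2c1ncn2/C=C1/CC1(CO)CO`, sits at the same limit: in this assay compound 2 gives > 20000 nM, again a limit rather than a measured value. The step that the two limits leave unreadable from compound 1 to compound 2 is therefore unreadable, and the limit of > 20000 nM in this assay, at which 2 of the 2 values shown sit, is all the two measurements show.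

Compound 3 `Nc1nc(OCc2ccccc2)c2ncn(/C=C3/CC3(CO)CO)c2n1` differs from compound 1 by phenyl in place of trifluoromethyl on a saturated chain carbon bound to an oxygen on an aromatic ring. Within the data shown here, no measured step carries this particular change. Among the measured compounds shown here, the only measured step, from compound 1 to compound 2, also alters the group on a saturated chain carbon bound to an oxygen on an aromatic ring, but its size is not readable, both values resting at the limit of > 20000 nM in this assay, at which 2 of the 2 values shown sit. With every measured value at the limit, the expectation for compound 3 is that this assay once more reports a limit. Compound 3 is estimated at 20000 nM, with a range from 8000 nM to 20000 nM. The expected step of a number no higher from compound 1 to compound 3 (the limit leaves the size open) is thus no step beyond the scatter.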

Compound 3, half-maximal cytotoxic concentration: > 20000 nM
Compound 3 gave a limit, no number; the forecaster's own chance of this, stated with the estimate: 80%; the middle value sits exactly at the limit.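

In this assay compound 3 gives > 20000 nM as a limit of the assay and not a number. Within the data shown here, no step among compound 1, compound 2 and compound 3 can be read: the limit of > 20000 nM in this assay, at which 3 of the 3 values shown sit.

The compounds shown leave open how far beyond that limit each of the three lies, and whether any ether on the shared core gives a measurable value in this assay at all.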